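The source may hold more compounds than are shown below. What is called first, only, known or untested is meant among the compounds shown, and "the series" means these compounds.

Working notes on the series. Compound 1 `Cc1cc(O)c(C2=NN(c3ccc(S(N)(=O)=O)cc3)C(c3ccccc3Cl)C2)cc1Cl` gives 2010 nM in a functional assay on DU-145 cells (Homo sapiens) for antiproliferative activity, with a stated time of 48 h; a lower number here means a stronger inhibitor of growth, a higher number a weaker inhibitor of growth. Within the data shown here, compound 2 `Cc1cc(O)c(C2=NN(c3ccc(S(N)(=O)=O)cc3)C(/C=C/c3ccccc3)C2)cc1Cl` gives 14100 nM in this assay, which is the highest of the two numbers measured so far; its nearest neighbour is compound 1, and the only measured step, a 7.0-fold higher number from compound 1 to compound 2 (0.85 log units; beyond the scatter), lies beyond the scatter. Compound 3 `COc1ccc(C2CC(c3cc(Cl)c(C)cc3O)=NN2c2ccc(S(N)(=O)=O)cc2)cc1OC` has not been measured. It differs from compound 2 by 3,4-dimethoxyphenyl in place of 2-phenylethenyl on a saturated ring carbon. Among the measured compounds shown here, no measured step covers a change from one aryl group to another on that saturated ring carbon; the one step that bears on the site is a 7.0-fold higher number from compound 1 to compound 2 (0.85 log units; beyond the scatter), which shows that replacing an aryl group there by 2-phenylethenyl raised the number. Reversing that kind of change, an aryl group returning in place of 2-phenylethenyl, is therefore expected to move the number back toward that of compound 1, so the step of a 4.0-fold lower number from compound 2 to compound 3 (0.61 log units; beyond the scatter) is expected to be a decrease. Compound 3 is expected to give about 3500 nM in this assay, within a range of 1200 nM to 11000 nM.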

Compound 3, concentration for 50% growth inhibition: 4490 nM
For compound 3 the middle estimate is 1.3-fold (0.11 log units) below the measured one; low and high end bracket the measured number.
By their numbers in this assay, from the lowest: compound 1; then compound 3; then compound 2.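

In this assay, a 3.1-fold lower number from compound 2 to compound 3 (0.50 log units; beyond the scatter) shows that a lower number than that of 2-phenylethenyl at this saturated ring carbon is not tied to 2-chlorophenyl alone, since 3,4-dimethoxyphenyl also gives one. The two aryl groups are not equivalent, however: a 2.2-fold higher number from compound 1 to compound 3 (0.35 log units; beyond the scatter) puts 3,4-dimethoxyphenyl short of 2-chlorophenyl by a step beyond the scatter, so the identity of the aryl substituents also matters at this site, and among the three groups the order from lowest number is 2-chlorophenyl, 3,4-dimethoxyphenyl, 2-phenylethenyl. No measurement at hand accounts for these differences.

On these data alone, how a plain phenyl, a saturated 2-phenylethyl chain or an aminophenyl group would compare at this carbon remains open. Also open, as far as these compounds go, is whether the chlorine or the position of substitution on the aryl ring goes with the lower number of compound 1.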